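Hydrogen in Place of Chloro in a Flat Series

The source may report more compounds than this note shows. Statements on the series, on what has been measured and on what is new or still open speak of the compounds shown alone.

The account covers three measured compounds and one that awaits measurement. Compound 1 `CC(C(=O)N1CCN(c2ccccc2)CC1)N1C(=O)CCC1=O` and compound 2 `CC(C(=O)N1CCN(c2ccc(Cl)cc2)CC1)N1C(=O)CCC1=O` share a core; compound 3 `CCC(C(=O)N1CCN(c2cccc(Cl)c2)CC1)N1C(=O)CCC1=O` has a core whose difference from that of compound 2 is not broken down here. In a functional assay on the whole organism (strain Swiss) with Mus musculus as the target, in the maximal electroshock model, with a stated time of 2 h, at a dose of 100 mg/kg by the intraperitoneal route (on this read-out lower numbers stand for a weaker effect and higher numbers for a stronger effect at the one dose given), compound 1 gives 0%. In this assay compound 2 gives 0% and compound 3 gives 0%.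

Going by the values given here, the one counted step runs from compound 2 to compound 1: hydrogen in place of chloro on an aromatic carbon, and it made no change at the digits printed from compound 2 to compound 1 (within the scatter). Compound 4 `CCC(C(=O)N1CCN(c2ccccc2)CC1)N1C(=O)CCC1=O` arises from compound 3 by hydrogen in place of chloro on an aromatic carbon. This is the same kind of change, not the same one: in the earlier pair the place is para to a large group, in the new pair meta to a large group.

Because compound 2 and compound 1 show no change at the digits printed from compound 2 to compound 1 (within the scatter), and because compound 3 gives 0%, the step from compound 3 to compound 4 is expected to be no change at the digits printed from compound 3 to compound 4 (within the scatter). For compound 4 in this assay the estimated value is therefore 0%, with a range from 0% to 10%.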

Compound 4, a percentage reported as activity, at one dose (the size of the read-out at that dose, not a potency): 0%
Beside the measured number, compound 4's estimate shows no gap at the digits printed, within the range that was stated.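

In this assay, hydrogen in place of chloro on an aromatic carbon made no change at the digits printed from compound 3 to compound 4 (within the scatter), and methyl in place of hydrogen on a saturated chain carbon made no change at the digits printed from compound 1 to compound 4 (within the scatter). Set beside the earlier step, the change from chloro to hydrogen carries from one core to the other with no gap between the two steps: the same change on two cores in this assay, no change at the digits printed (within the scatter) from compound 2 to compound 1 and no change at the digits printed (within the scatter) from compound 3 to compound 4, 0 percentage points apart, within the scatter of two such steps Yet compound 1, compound 2 and compound 3 all read the same as compound 4 at 0%, so this agreement shows only that the change leaves that reading in place on these two cores, and it does not show how the change would act on a core that gives a reading above that level.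

The compounds shown leave open whether another group on the aromatic ring, such as methoxy or trifluoromethyl, would give a different reading. They also leave open whether a longer chain at the saturated chain carbon would do so.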